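The compounds below may be only part of what the source reports. "The series", "measured", "known", "first", "only" and "open" are said of these compounds alone.

Three compounds share one core and were tested in a functional assay on the whole organism with Rattus norvegicus as the target; a lower number here means that less compound is needed, a higher number that more compound is needed for the effect. Compound 1 `CC1CCC(=NNc2ccccc2C(=O)O)c2ncc(C(=O)NO)c(=O)n21` gives only a limit in this assay, > 100 umol/kg. Compound 2 `Cc1ccc(NN=C2CCC(C)n3c2ncc(C(=O)O)c3=O)cc1C` likewise gives only a limit in this assay, > 100 umol/kg. Compound 3 `Cc1cc(C)c(NN=C2CCC(C)n3c2ncc(C(=O)O)c3=O)cc1C` gives 320 umol/kg in this assay. The step from compound 2 to compound 3, methyl in place of hydrogen on an aromatic carbon, is a step that the limit leaves unreadable from compound 2 to compound 3. Compound 2 thus stands at the limit of > 100 umol/kg in this assay, at which 2 of the 3 values shown sit. Compound 4 `CC1CCC(=NNc2c(Cl)cccc2Cl)c2ncc(C(=O)O)c(=O)n21` differs from compound 2 in one place: 2,6-dichlorophenyl in place of 3,4-dimethylphenyl on an amine nitrogen. Going by the values given here, no measured step of this kind is known, and compound 2 offers only a limit, so nothing sets a direction. Compound 4 is therefore expected to stay weak, with an estimated step that the limit leaves unreadable from compound 2 to compound 4 and an expected value near 300 umol/kg, ranging from 100 umol/kg to 1000 umol/kg.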

Compound 4, dose for 50% inhibition: > 100 umol/kg
Compound 4: a limit, no number (the forecaster's own chance of this, stated with the estimate: 60%); the middle value lies beyond the limit too.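

Compound 2 and compound 4 each give only a limit in this assay, not a number, and the step between them cannot be read. Still open, from the compounds shown here alone, is what dose either compound needs, and whether 2,6-dichlorophenyl in place of 3,4-dimethylphenyl changes it at all.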